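Methyl and Methoxy Changes on a Fused Ring Growth Inhibitor

The compounds below may be only part of what the source reports. "The series", "measured", "known", "first", "only" and "open" are said of these compounds alone.

Compound 1 `COC(=O)[C@@]1(C)CCC=C2[C@@H]1CC[C@@H](C)[C@]2(C)Cc1c[nH]c2ccc(F)cc12` is the reference. In a functional assay on HBL-100 cells (Homo sapiens) for inhibition, read by sulforhodamine B assay, with a stated time of 48 h (a lower number here means a stronger inhibitor of growth, a higher number a weaker inhibitor of growth), compound 1 gives 4800 nM. Compound 2 `COC(=O)[C@@]1(C)CCC=C2[C@@H]1CC[C@@H](C)[C@]2(C)Cc1c[nH]c2ccc(OC)cc12` differs from it by one change, (methoxy in place of fluoro on an aromatic carbon), and in this assay compound 2 gives 2100 nM, so that a 2.3-fold lower number from compound 1 to compound 2 (0.36 log units; beyond the scatter). Compound 3 `COC(=O)[C@@]1(C)CCC=C2[C@@H]1CC[C@@H](C)[C@]2(C)Cc1c(C)[nH]c2ccc(F)cc12` carries a different core; the difference is methyl in place of hydrogen on an aromatic carbon. In this assay compound 3 gives 14000 nM, and a 2.9-fold higher number from compound 1 to compound 3 (0.46 log units; beyond the scatter). Compound 4 `COC(=O)[C@@]1(C)CCC=C2[C@@H]1CC[C@@H](C)[C@]2(C)Cc1c(C)[nH]c2ccc(OC)cc12` is not yet measured; it differs from compound 3 by methoxy in place of fluoro on an aromatic carbon, the same change already seen from compound 1 to compound 2, which occurs twice among these compounds. Because a 2.3-fold lower number from compound 1 to compound 2 (0.36 log units; beyond the scatter), a step of similar size is expected here, namely a 2.2-fold lower number from compound 3 to compound 4 (0.33 log units; beyond the scatter). Compound 4 is therefore estimated to give 6500 nM in this assay, roughly between 2500 nM and 16000 nM.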

Compound 4, concentration for 50% growth inhibition: 16000 nM
Estimate against measurement, compound 4: 2.5-fold (0.39 log units) below; measured number inside the range.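

In this assay, methoxy in place of fluoro on the core of compound 3 gives a 1.1-fold higher number from compound 3 to compound 4 (0.06 log units; within the scatter), so no real change can be claimed for this step. This step looks different from the earlier one, but two pairs cannot show that the effect of the swap depends on the core, nor that it carries over unchanged: the same change on two cores in this assay, a 2.3-fold lower number (0.36 log units; beyond the scatter) from compound 1 to compound 2 and a 1.1-fold higher number (0.06 log units; within the scatter) from compound 3 to compound 4, 2.6-fold (0.42 log units) apart, within the scatter of two such steps. Methyl in place of hydrogen gives a 7.6-fold higher number from compound 2 to compound 4 (0.88 log units; beyond the scatter), the same direction as before, with no gap beyond the scatter: the same change on two cores in this assay, a 2.9-fold higher number (0.46 log units; beyond the scatter) from compound 1 to compound 3 and a 7.6-fold higher number (0.88 log units; beyond the scatter) from compound 2 to compound 4, 2.6-fold (0.42 log units) apart, within the scatter of two such steps.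

On these data alone, whether a chloro group, an amine or a carboxylic acid in place of fluoro would follow either pattern remains open. So does whether these steps hold on any core beyond the two shown.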